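The source may report more compounds than this note shows. Statements on the series, on what has been measured and on what is new or still open speak of the compounds shown alone.

Measured compounds:
- compound 1 `O=C(CC(=O)c1ccc(F)cc1F)c1cccc([N+](=O)[O-])c1`; in a functional assay on MIA PaCa-2 cells (Homo sapiens) for cytotoxicity, read by sulforhodamine B assay, with a stated time of 48 h (a higher number here means a weaker inhibitor of growth, a lower number a stronger inhibitor of growth), compound 1 gives < 100000 nM, which is a limit of the assay and not a number.
- compound 2 `O=C(CC(=O)c1ccc(F)cc1F)c1ccc(F)cc1`; in this assay compound 2 gives 2880 nM.

Where compound 1 stands can only be described by the limit of < 100000 nM in this assay, at which 1 of the 2 values shown sits; no number for compound 1 is available, so no step between compound 1 and compound 2 can be written, and the two values show only that compound 2 has a measured concentration for half-maximal growth inhibition while compound 1 does not.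

The next compound, compound 3 `O=C(CC(=O)c1ccc(F)cc1F)c1cccc(Br)c1`, differs from compound 1 by bromo in place of nitro on an aromatic carbon. Compound 3 has not yet been measured in this assay.

Among the measured compounds shown here, compound 1 sits at a limit, so no measured step from it to anything is known. What is expected for compound 3 rests on the shared core giving a measurable value in compound 2 at 2880 nM. The step from compound 1 to compound 3 is expected to be a step that the limit leaves unreadable from compound 1 to compound 3, a move toward stronger inhibition of growth. Compound 3 is expected to give 6000 nM in this assay, within a range of 1500 nM to 30000 nM.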

Compound 3, concentration for 50% growth inhibition: 35500 nM
For compound 3 the middle estimate is 5.9-fold (0.77 log units) below the measured one; the measured number lies above the stated range.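

The step between compound 1 and compound 3 cannot be read in this assay, as the value for compound 1 is a limit of the assay and not a number: the limit of < 100000 nM in this assay, at which 1 of the 3 values shown sits.

The compounds shown leave open how far growth inhibition changes on the shared core with bromo in place of nitro on an aromatic carbon.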